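The source may report more compounds than this note shows. Statements on the series, on what has been measured and on what is new or still open speak of the compounds shown alone.

Of the compounds shown here, two have been measured in an assay on microsomes from liver for inhibition of 3-hydroxy-3-methylglutaryl-coenzyme A reductase (Rattus norvegicus); on this read-out higher numbers stand for weaker inhibition and lower numbers for stronger inhibition. Compound 1 `CC[C@H](C)C(=O)O[C@H]1C[C@H](O)C=C2C=C[C@H](C)[C@H](CCC(O)C[C@H](O)CC(=O)O)[C@]21C` has the lowest number of the pair, giving 5 nM in this assay. Compound 2 `Cc1ccc(-c2nc(C(F)(F)F)n(CC[C@@H](O)C[C@@H](O)CC(=O)O)c2-c2ccc(F)cc2)cc1` stands at the other end: in this assay compound 2 gives 43 nM, the highest of the two numbers, and its nearest neighbour, compound 1, sits well beyond the scatter below it. The two share the 6-carboxy-3,5-dihydroxyhexyl side chain but differ in everything around it, so the gap between them says nothing about any single group.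

Compound 3 `Cc1cc(C)cc(-c2nc(C(F)(F)F)n(CC[C@@H](O)C[C@@H](O)CC(=O)O)c2-c2ccc(F)cc2)c1` has not yet been measured. It differs from compound 2 in one place: 3,5-dimethylphenyl in place of 4-methylphenyl on an aromatic carbon. Going by the values given here, no measured pair shows this particular change, so its effect has to be guessed. Since compound 2 already gives 43 nM and the change adds one carbon to an aromatic ring next to the ring nitrogen, the step from compound 2 to compound 3 is expected to be small, either none beyond the scatter or a modest weakening, a 1.6-fold higher number from compound 2 to compound 3 (0.21 log units; within the scatter). Compound 3 is therefore estimated to give 70 nM in this assay, with a range from 25 nM to 200 nM.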

Compound 3, half-maximal inhibitory concentration: 24 nM
Compound 3: middle estimate off by 2.9-fold (0.46 log units), on the high side; the measured number lies below the stated range.
By their numbers in this assay, from the lowest: compound 1; then compounds 3 and 2 (each within the scatter of the next).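

In this assay, putting 3,5-dimethylphenyl in place of 4-methylphenyl on this aromatic carbon of the five-membered ring gives a 1.8-fold lower number from compound 2 to compound 3 (0.25 log units; within the scatter), so the added methyl group and the altered placement of methyl on the phenyl ring produce no difference that can be told from repeat scatter. Going by these compounds alone, this is the first pair that isolates a single place, since compound 1 and compound 2 differ in everything around their shared side chain and could say nothing about this position. No measurement available here bears on why the two phenyl groups read alike.

The compounds shown leave open whether this position would read the same with a phenyl ring lacking methyl groups, with a polar substituent such as a methoxy group or an amine on the ring, or with a larger group such as naphthyl. On these data alone, the 4-fluorophenyl and trifluoromethyl groups stay fixed across compound 2 and compound 3, so it also remains open whether the step would hold with an isopropyl group in place of trifluoromethyl.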